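Repositioning a methoxyphenyl group: from compound 2 to compound 3

The compounds below may be only part of what the source reports. "The series", "measured", "known", "first", "only" and "open" are said of these compounds alone.

Compounds measured so far:
compound 1, `COC(OC)C1=C(C(=O)OC/C=C/c2cccc(Cl)c2)C(c2cccc(Cl)c2)C(C(=O)O)=C(C)N1`, 1000 nM
compound 2, `COc1ccccc1/C=C/COC(=O)C1=C(C(OC)OC)NC(C)=C(C(=O)O)C1c1cccc(Cl)c1`, 5900 nM

For the measured compounds named here, in an assay on thoracic aorta for inhibition of Voltage-gated L-type calcium channel (Rattus norvegicus) (on this read-out higher numbers stand for weaker inhibition and lower numbers for stronger inhibition), compound 2 gives 5900 nM, the highest of the two numbers known here. Its nearest neighbour is compound 1, and the step of a 5.9-fold higher number from compound 1 to compound 2 (0.77 log units; beyond the scatter) was judged modest but beyond the scatter. Compound 3, `COc1ccc(/C=C/COC(=O)C2=C(C(OC)OC)NC(C)=C(C(=O)O)C2c2cccc(Cl)c2)cc1`, differs from compound 2 by 4-methoxyphenyl in place of 2-methoxyphenyl on a double-bonded chain carbon bound to a double-bonded chain carbon. Going by the values given here, no measured step covers this change: the one known step exchanges a chloro-substituted ring for a methoxy-substituted one, not a move of the methoxy group within the ring. The expectation therefore rests on little, and the step of a 1.5-fold lower number from compound 2 to compound 3 (0.17 log units; within the scatter) is estimated to stay within or near the scatter. Compound 3 is estimated at 4000 nM in this assay, with a range from 1200 nM to 15000 nM.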

Compound 3, half-maximal inhibitory concentration: 540 nM
The estimate for compound 3 lay 7.4-fold (0.87 log units) above the measured number; measured number outside the range, below it.
By their numbers in this assay, from the lowest: compounds 3 and 1 (each within the scatter of the next); then compound 2.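

In this assay, for the compounds shown here, the place of the methoxy group on the ring proves to matter: 4-methoxyphenyl in place of 2-methoxyphenyl gives an 11-fold lower number from compound 2 to compound 3 (1.04 log units; beyond the scatter), a step made with the same atoms joined differently, which the single earlier step could not show. Set against the 3-chlorophenyl group, 4-methoxyphenyl gives a 1.9-fold lower number from compound 1 to compound 3 (0.27 log units; within the scatter), so among these three compounds the higher number goes with the 2-methoxyphenyl group alone and not with every methoxyphenyl group. No evidence at hand bears on the reason for this difference.

The compounds shown leave open whether a 3-methoxyphenyl group on this chain would stand with compound 2 or with compound 3. They also leave open whether a 2-chlorophenyl or 4-chlorophenyl group would show the same dependence on place.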